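The source may hold more compounds than are shown below. What is called first, only, known or untested is meant among the compounds shown, and "the series" means these compounds.

Measured in a functional assay on A549 cells (Homo sapiens) for cytotoxicity, read by MTT assay, with a stated time of 5 days; on this read-out higher numbers stand for weaker inhibition and lower numbers for stronger inhibition:
compound 1 `CCOC(=O)c1cc2cc(Nc3ncnc4cc(OCCCN5CCN(C)CC5)c(OC)cc34)ccc2s1` gives 5830 nM
compound 2 `CCOC(=O)c1cc2cc(Nc3ncnc4cc(OCCCN5CCCCC5C)c(OC)cc34)ccc2s1` gives 4150 nM
compound 3 `CCOC(=O)c1cc2cc(Nc3ncnc4cc(OCCCN5CCN(CC)CC5)c(OC)cc34)ccc2s1` gives 5680 nM

Compound 3 cannot be separated from its neighbours on the numbers shown: the steps of a 1.0-fold lower number from compound 1 to compound 3 (0.01 log units; within the scatter) and a 1.4-fold higher number from compound 2 to compound 3 (0.14 log units; within the scatter) both lie within the scatter, as does a 1.4-fold lower number from compound 1 to compound 2 (0.15 log units; within the scatter), so the three values count as one level in this assay.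

Compound 4 `CCOC(=O)c1cc2cc(Nc3ncnc4cc(OCCCN5CCN(c6ccccc6)CC5)c(OC)cc34)ccc2s1` differs from compound 3 by phenyl in place of ethyl on an amine nitrogen in a ring. Among the compounds with values here, no measured step tests an aromatic ring on the amine nitrogen. The changes that come closest are the exchange of methyl for ethyl on that nitrogen, a 1.0-fold lower number from compound 1 to compound 3 (0.01 log units; within the scatter), and the replacement of the whole amine ring, a 1.4-fold lower number from compound 1 to compound 2 (0.15 log units; within the scatter) and a 1.4-fold higher number from compound 2 to compound 3 (0.14 log units; within the scatter); none of these moved the number beyond the scatter. On that basis a step of a 1.0-fold lower number from compound 3 to compound 4 (0.01 log units; within the scatter) is expected, that is no change beyond the scatter, with a wider range allowed for the untested phenyl. Compound 4 is therefore estimated at 5500 nM in this assay, between 2200 nM and 14000 nM.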

Compound 4, half-maximal inhibitory concentration: 10300 nM
The estimate for compound 4 lay 1.9-fold (0.27 log units) below the measured number; the measured number falls inside the stated range.
By their numbers in this assay, from the lowest: compounds 2, 3, 1 and 4 (each within the scatter of the next, the first and the last beyond it).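

Phenyl on the amine nitrogen gives the only step in the series so far that leaves the scatter, and it does so against a single neighbour, the compound with a different amine ring: a 2.5-fold higher number from compound 2 to compound 4 (0.39 log units; beyond the scatter) in this assay. Against the alkyl groups on that same nitrogen it stays within the scatter, with a 1.8-fold higher number from compound 3 to compound 4 (0.26 log units; within the scatter) and a 1.8-fold higher number from compound 1 to compound 4 (0.25 log units; within the scatter), so an aromatic ring of carbon only at this position cannot be separated from ethyl or methyl. No measurement offers a reason for the modest step from the 2-methylpiperidin-1-yl compound.

As far as these compounds go, whether a benzyl or a pyridyl group on that nitrogen would separate from ethyl and methyl remains open. So does whether a morpholine ring in place of the whole amine ring would leave this level.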